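This account rests on a few compounds, and the source may have more. Where it says the series, first, only, none or still open, it means among the compounds named here.

In an in vitro functional assay on cells for agonist activity at Bombesin receptor subtype-3 (Mus musculus), read by luminescence and calcium flux (a lower number here means that less compound is needed, a higher number that more compound is needed for the effect), compound 2 `COc1cccc(Cc2cnc(CCc3ccc(-c4ccccc4C(=O)O)cc3)[nH]2)c1` gives 79 nM, the second highest of the three numbers reported. Its nearest neighbour, compound 1 `O=C(O)c1ccccc1-c1ccc(CCc2ncc(CC3CCCC3)[nH]2)cc1`, gives 7.9 nM in this assay, while the furthest, compound 3 `CCCCc1cnc(C(Cc2ccc(-c3ccccc3C(=O)O)cc2)C(C)C)[nH]1`, gives 2240 nM. The change now considered leads to compound 4 `O=C(O)c1ccccc1-c1ccc(CCc2ncc(CCc3ccccc3)[nH]2)cc1` through (benzyl in place of 3-methoxyphenyl on a saturated chain carbon bound to an aromatic carbon). Within the data shown here, the only measured step on this part of the molecule is a 10-fold higher number from compound 1 to compound 2 (1.00 log units; beyond the scatter), which shows that what sits on the saturated chain carbon bound to the aromatic carbon can move the number well beyond the scatter. Among the measured compounds shown here, no measured pair separates the methoxy group from the rest of that change, and no step isolates the added chain carbon, so the direction is uncertain. Compound 4 keeps an aromatic ring at that position, as compound 2 does, and the step is expected to be a 2.0-fold lower number from compound 2 to compound 4 (0.30 log units; within the scatter), a modest lowering judged somewhat more likely than a rise. Compound 4 is therefore estimated at 40 nM, within a range of 10 nM to 160 nM.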

Compound 4, half-maximal effective concentration: 174 nM
Compound 4: the middle estimate sits 4.4-fold (0.64 log units) below what was measured; the whole stated range lies below it.
By their numbers in this assay, from the lowest: compound 1; then compound 2; then compound 4; then compound 3.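

In this assay, benzyl in place of 3-methoxyphenyl on a saturated chain carbon bound to an aromatic carbon gives a 2.2-fold higher number from compound 2 to compound 4 (0.34 log units; beyond the scatter), so this change also moves the number beyond the scatter, and the direction is upward. Benzyl in place of cyclopentyl gives a 22-fold higher number from compound 1 to compound 4 (1.34 log units; beyond the scatter), which leaves the cyclopentyl of compound 1 with a lower number than either group carrying an aromatic ring among these compounds. The data shown give no explanation for either step.

The compounds shown do not separate the loss of the methoxy group from the added chain carbon, so neither contribution can be read alone. Also open, on these data alone, is how a cyclohexyl group, a longer unbranched chain or an amine at this place would compare with cyclopentyl.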